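Para-halogen swap on the pendant phenyl of compound 3

The source may hold more compounds than are shown below. What is called first, only, known or untested is meant among the compounds shown, and "the series" means these compounds.

Compound 3 `Fc1ccc(-c2cn3ccnc3c(-c3ccc4ncn(C5CCCCC5)c4c3)n2)cc1` gives 33.4% in a functional assay on CCRF-CEM cells (Homo sapiens) for inhibition, read by sulforhodamine B assay, with a stated time of 48 h, tested at 10 uM (a lower number here means less inhibition, a higher number more inhibition at the concentration tested (going by the name of the read-out)), and stands second highest of the three measured numbers. Compound 1 `Brc1cn2ccnc2c(-c2ccc3ncn(C4CCCCC4)c3c2)n1` gives 7.68% and compound 2 `O=Cc1ccc(-c2cn3ccnc3c(-c3ccc4ncn(C5CCCCC5)c4c3)n2)cc1` gives 77.9% in this assay. Compound 4 `Clc1ccc(-c2cn3ccnc3c(-c3ccc4ncn(C5CCCCC5)c4c3)n2)cc1` differs from compound 3 by chloro in place of fluoro on an aromatic carbon. Going by the values given here, no measured step exchanges one halogen for another; the nearest steps are a number 25.7 percentage points higher from compound 1 to compound 3 (beyond the scatter) and a number 44.5 percentage points lower from compound 2 to compound 3 (beyond the scatter), which touch the same ring position with other groups, and a number 70.2 percentage points higher from compound 1 to compound 2 (beyond the scatter). Among the compounds with values here, with no direct precedent the step of a number 6.6 percentage points higher from compound 3 to compound 4 (within the scatter) is expected to stay near the scatter, leaning slightly higher. Compound 4 is estimated at 40%, within 22% to 62%.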

Compound 4, a percentage reported as inhibition, at one concentration (the size of the read-out at that concentration, not a potency): 11.4%
The estimate for compound 4 lay 28.6 percentage points above the measured number; measured number below the stated range.
By their numbers in this assay, from the lowest: compounds 1 and 4 (each within the scatter of the next); then compound 3; then compound 2.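

In this assay, exchanging one halogen for another on the pendant ring is not a silent change: 4-fluorophenyl to 4-chlorophenyl gives a number 22 percentage points lower from compound 3 to compound 4 (beyond the scatter). The step of a number 3.7 percentage points higher from compound 1 to compound 4 (within the scatter) shows that a substituted phenyl in place of bromo need not raise the number, and the formyl group stands well apart, with a number 66.5 percentage points lower from compound 2 to compound 4 (beyond the scatter). Nothing at hand gives a reason for these differences.

Open, going by these compounds, is whether the higher number depends on the formyl group itself: a carboxylic acid, a hydroxymethyl group or an amine in its place would test this. A bromo group in place of chloro on the same ring would extend the halogen comparison.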